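The compounds below may be only part of what the source reports. "The series", "measured", "known", "first", "only" and "open" are said of these compounds alone.

Working notes on the series in a functional assay on PC-3 cells (Homo sapiens) for inhibition; on this read-out higher numbers stand for weaker inhibition and lower numbers for stronger inhibition.

For the measured compounds named here, compound 1 `Cc1c(C(=O)N/N=C\c2cccc(O)c2O)oc2cccc(O)c12` is the only member of the set with a number on this read-out: in this assay compound 1 gives 12200 nM. Compound 2 `Cc1c(C(=O)N/N=C\c2ccco2)oc2cccc(O)c12` gives only a limit of this assay, >= 40000 nM, and no number. Going by the values given here, the one measured step, an at least 3.2-fold higher number from compound 1 to compound 2 (0.51 log units; beyond the scatter), is therefore open at its upper end; its size follows from the limit of >= 40000 nM in this assay, at which 1 of the 2 values shown sits.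

Compound 3 `Cc1c(C(=O)N/N=C\c2ccc(Br)cc2O)oc2cccc(O)c12` differs from compound 1 by 4-bromo-2-hydroxyphenyl in place of 2,3-dihydroxyphenyl on a carbon with a double bond to nitrogen. The measured step bears on this only in part: in that step both hydroxyl groups left together with the ring type, whereas here one hydroxyl group remains and bromine enters on the same aromatic ring. A step in the same direction as from compound 1 to compound 2, but smaller, is expected; a result within the scatter cannot be excluded.

The estimate for compound 3 is 22000 nM (range 7000 nM to 60000 nM), which means an expected step of a 1.8-fold higher number from compound 1 to compound 3 (0.26 log units; within the scatter).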

Compound 3, half-maximal inhibitory concentration: 2050 nM
Compound 3: middle estimate off by 11-fold (1.03 log units), on the high side; the whole stated range lies above it.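

The position on a carbon with a double bond to nitrogen can move the read-out in this assay in both directions, which the earlier pair could not show: 4-bromo-2-hydroxyphenyl in place of 2,3-dihydroxyphenyl gives a 6.0-fold lower number from compound 1 to compound 3 (0.77 log units; beyond the scatter), opposite in direction to the furan-2-yl change. The two hydroxyl groups of compound 1 are therefore not both required for a measurable number here, since compound 3, with one hydroxyl group and a bromine on the same aromatic ring, has the lowest number of the three. The spread across this position is also wider than the first step suggested, with an at least 19-fold lower number from compound 2 to compound 3 (1.29 log units; beyond the scatter), and this step stays open at its end: the limit of >= 40000 nM in this assay, at which 1 of the 3 values shown sits.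

For the compounds shown here, the single step removes a hydroxyl group and brings in bromine together, so the share of each in the change remains unresolved, and 2-hydroxyphenyl alone or 4-bromophenyl would separate them. Going by these compounds, whether bromine itself matters also remains open, as chlorine, a methoxy group or an amine in its place would test.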